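This account rests on a few compounds, and the source may have more. Where it says the series, first, only, none or still open, it means among the compounds named here.

Measured compounds:
Compound 1 `Cc1cc(C(=O)NC(C)C)nn1Cc1cc(Cl)cc2cc(-c3ccccc3)oc12` gives 10 nM in an assay on CHO-K1 cells for displacement of a labelled ligand from prostaglandin E2 receptor EP1 subtype (Homo sapiens), read by scintillation counting, with a stated time of 45 min; on this read-out lower numbers stand for stronger inhibition and higher numbers for weaker inhibition.
Compound 2 `Cc1cc(C(=O)NC2CC2)nn1Cc1cc(Cl)cc2cc(-c3ccccc3)oc12` gives 5.01 nM in this assay.

Among the measured compounds shown here, compound 2 holds the lowest of the two numbers, but its only neighbour is compound 1, and the step of a 2.0-fold lower number from compound 1 to compound 2 (0.30 log units; within the scatter) is within the scatter, so the two cannot be told apart on these data.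

Compound 3 `Cc1cc(NC(=O)CC2CCNCC2)nn1Cc1cc(Cl)cc2cc(-c3ccccc3)oc12` differs from compound 2 in one place: (((piperidin-4-yl)methyl)carbonyl)amino in place of cyclopropylcarbamoyl on an aromatic carbon. This is a different kind of change from the one measured so far. For the measured compounds named here, the single known step swaps one small group for another on the amide nitrogen while the amide itself stays put, and that step, a 2.0-fold lower number from compound 1 to compound 2 (0.30 log units; within the scatter), was within the scatter. Going by the values given here, in compound 3 the amide is turned around and a larger group with a second ring is attached, and no measured pair speaks to that. Among the compounds with values here, the one measured step shows only that this part of the molecule tolerates a small swap without a shift beyond the scatter.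

Within the data shown here, with no directly comparable step, the expectation for compound 3 in this assay is a modest loss, an 8.0-fold higher number from compound 2 to compound 3 (0.90 log units; beyond the scatter), with wide uncertainty. Compound 3 is therefore estimated at 40 nM, with a range from 5 nM to 400 nM.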

Compound 3, half-maximal inhibitory concentration: 63.1 nM
The estimate for compound 3 lay 1.6-fold (0.20 log units) below the measured number; the measured number falls inside the stated range.
By their numbers in this assay, from the lowest: compounds 2 and 1 (each within the scatter of the next); then compound 3.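

In this assay, putting (((piperidin-4-yl)methyl)carbonyl)amino in place of cyclopropylcarbamoyl gives a 13-fold higher number from compound 2 to compound 3 (1.10 log units; beyond the scatter) and in place of isopropylcarbamoyl gives a 6.3-fold higher number from compound 1 to compound 3 (0.80 log units; beyond the scatter) on the same aromatic carbon. The earlier compounds shown here showed only that one small amide substituent could replace another here without a shift beyond the scatter, whereas these steps show that this position does respond to a bigger change, one that turns the amide around and adds a six-membered non-aromatic ring with a hetero atom. Compound 3 still gives 63.1 nM as a measurable number, so the position accepts this larger group at a cost, though no supporting measurement is available to explain that cost.

The compounds shown change the amide direction and the attached group together, so they leave open how much of the step belongs to each. A turned-around amide carrying a plain cyclopropyl group would address the first part, while a cyclohexyl ring in place of the piperidine ring would test whether the ring nitrogen matters.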